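The source may report more compounds than this note shows. Statements on the series, on what has been measured and on what is new or still open speak of the compounds shown alone.

Measured in a functional assay on PC9/GR4 cells (Homo sapiens) for antiproliferative activity, read by luminescence, with a stated time of 72 h; a higher number here means a weaker inhibitor, a lower number a stronger inhibitor:
- compound 1 `NC(=O)Nc1ccc2ncnc(Nc3ccc(F)c(Cl)c3)c2c1`: 21700 nM
- compound 2 `CC(=O)Nc1ccc2ncnc(Nc3ccc(OCc4cccc(F)c4)c(Cl)c3)c2c1`: 8310 nM
- compound 3 `O=C(NCCN1CCCCC1)Nc1ccc2ncnc(Nc3ccc(OCc4cccc(F)c4)c(Cl)c3)c2c1`: 2160 nM

Compound 3 has the lowest number of the three in this assay. Compound 4 `Fc1cccc(COc2ccc(Nc3ncnc4ccc(NC(=S)NCCN5CCCCC5)cc34)cc2Cl)c1` has not yet been measured. It differs from compound 3 as follows: a group of 11 heavy atoms (8 carbon, 2 nitrogen, 1 sulfur; one six-membered non-aromatic ring with 1 hetero atom) in place of a group of 11 heavy atoms (8 carbon, 2 nitrogen, 1 oxygen; one six-membered non-aromatic ring with 1 hetero atom), on a nitrogen on an aromatic ring. Sulfur thus replaces oxygen, while the six-membered non-aromatic ring remains.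

Among the measured compounds shown here, only one measured step bears on this change, and only indirectly: a 3.8-fold lower number from compound 2 to compound 3 (0.59 log units; beyond the scatter), a modest step with (2-(piperidin-1-yl)ethyl)amino in place of methyl on a carbonyl carbon. For the measured compounds named here, no measured pair exchanges oxygen for sulfur, so the series gives no direct size or direction for this change. Compound 4 is therefore expected to stay close to compound 3, with no step beyond the scatter and neither direction favoured. The expected step is a 1.0-fold higher number from compound 3 to compound 4 (0.01 log units; within the scatter). For compound 4 the estimated value is 2200 nM. The expected range for compound 4 runs from 800 nM to 6000 nM.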

Compound 4, half-maximal inhibitory concentration: 5700 nM
The estimate for compound 4 lay 2.6-fold (0.41 log units) below the measured number; measured number inside the range.
By their numbers in this assay, from the lowest: compound 3; then compounds 4 and 2 (each within the scatter of the next); then compound 1.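

In this assay, sulfur in place of oxygen in the group on the nitrogen on an aromatic ring is not a silent exchange, giving a 2.6-fold higher number from compound 3 to compound 4 (0.42 log units; beyond the scatter), a modest step. With sulfur present, the group carrying the piperidine ring no longer stands clear of the small methyl-bearing group, giving a 1.5-fold lower number from compound 2 to compound 4 (0.16 log units; within the scatter), whereas the oxygen version gave a 3.8-fold lower number from compound 2 to compound 3 (0.59 log units; beyond the scatter). No supporting measurement on hand accounts for the size of this step.

Still open, on these data alone, is whether the oxygen-to-sulfur step keeps its size with methyl on the same carbon rather than the (2-(piperidin-1-yl)ethyl)amino group. Also open, as far as these compounds go, is how it behaves with a morpholine ring in place of the piperidine ring, with a dimethylamino group, or with a longer chain.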